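Halogen Exchange on the Shared Core: Compound 3 to Compound 4

The compounds below may be only part of what the source reports. "The series", "measured", "known", "first", "only" and "open" are said of these compounds alone.

Compound 1, `CC#CC1=C(N)[C@@]2(OS1(=O)=O)[C@@H](CO[Si](C)(C)C(C)(C)C)O[C@@H](n1cc(C)c(=O)n(C)c1=O)[C@@H]2O[Si](C)(C)C(C)(C)C`, gives 5000 nM
Compound 2, `C=CCC1=C(N)[C@@]2(OS1(=O)=O)[C@@H](CO[Si](C)(C)C(C)(C)C)O[C@@H](n1cc(C)c(=O)n(C)c1=O)[C@@H]2O[Si](C)(C)C(C)(C)C`, gives 45000 nM
Compound 3, `Cc1cn([C@@H]2O[C@H](CO[Si](C)(C)C(C)(C)C)[C@@]3(OS(=O)(=O)C(Cl)=C3N)[C@H]2O[Si](C)(C)C(C)(C)C)c(=O)[nH]c1=O`, gives 7000 nM

In a functional assay on CCRF-CEM cells (Homo sapiens) (a lower number here means that less compound is tolerated, a higher number that more compound is tolerated), compound 3 stands second highest of the three measured numbers, close to compound 1 and clearly apart from compound 2. Among the compounds with values here, the one measured step, a 9.0-fold higher number from compound 1 to compound 2 (0.95 log units; beyond the scatter), concerns a different substituent and does not bear on an exchange of one halogen for another. Compound 4, `Cc1cn([C@@H]2O[C@H](CO[Si](C)(C)C(C)(C)C)[C@@]3(OS(=O)(=O)C(I)=C3N)[C@H]2O[Si](C)(C)C(C)(C)C)c(=O)[nH]c1=O`, differs from compound 3 in one place: iodo in place of chloro on a double-bonded ring carbon. Within the data shown here, no measured pair shows what this exchange does on the shared core, so the expected step of a 1.2-fold lower number from compound 3 to compound 4 (0.07 log units; within the scatter) is taken to lie within the scatter, in no particular direction. Compound 4 is therefore estimated at 6000 nM, with a range from 2000 nM to 20000 nM.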

Compound 4, half-maximal cytotoxic concentration: 4000 nM
Compound 4: the middle estimate sits 1.5-fold (0.18 log units) above what was measured; measured number inside the range.
By their numbers in this assay, from the lowest: compounds 4, 1 and 3 (each within the scatter of the next); then compound 2.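

In this assay, within the data shown here, iodo in place of chloro on a double-bonded ring carbon gives a 1.8-fold lower number from compound 3 to compound 4 (0.24 log units; within the scatter) as the first reading of a halogen exchange at this position on the shared core. Chloro and iodo cannot be told apart here, unlike the earlier step of a 9.0-fold higher number from compound 1 to compound 2 (0.95 log units; beyond the scatter) with allyl in place of prop-1-yn-1-yl on the same ring carbon. Nothing available explains why this exchange reads as it does. From the compounds shown here alone, what a bromo, a nitrile or a carboxylic acid on this carbon would give on the core of compound 3 remains open.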